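The source may hold more compounds than are shown below. What is called first, only, known or untested is meant among the compounds shown, and "the series" means these compounds.

Compound 3 `N#CCCCn1c(Cn2c(=O)n(C(F)F)c3ccncc32)nc2ccccc21` is one of three compounds tested in an ADME assay on HEp-2 cells (Homo sapiens) for cytotoxicity; on this read-out higher numbers stand for lower toxicity in this test and lower numbers for higher toxicity in this test. In this assay compound 3 gives > 205000 nM, which is a limit of the assay rather than a number. Compound 1 `CC(C)S(=O)(=O)n1c(=O)n(Cc2nc3ccccc3n2CCCC#N)c2cnccc21` gives > 228000 nM, also a limit. Going by the values given here, the one step between measured compounds that differ in a single place, a step that the two limits leave unreadable from compound 1 to compound 3, is therefore unreadable, since both ends are limits. Compound 4 `O=c1n(Cc2nc3ccccc3n2CCCCO)c2cnccc2n1C(F)F` differs from compound 3 by hydroxymethyl in place of cyano on a saturated chain carbon, three bonds along the chain from an aromatic nitrogen. Among the compounds with values here, no measured step covers this change, but compound 2 `O=c1n(Cc2nc3ccccc3n2CCCCO)c2cnccc2n1C1CCCC1`, which carries the 4-hydroxybutyl chain that enters here, gives > 246000 nM, likewise a limit. No step beyond the scatter is expected in a step that the limit leaves unreadable from compound 3 to compound 4, and compound 4 is expected to give 230000 nM, between 100000 nM and 500000 nM, most probably once more as a limit.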

Compound 4, half-maximal cytotoxic concentration: > 186000 nM
Compound 4 gave a limit, no number; the forecaster's own chance of this, stated with the estimate: 85%; the middle value is on the limit's open side.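

Compound 4 also ends at a limit of the assay, so its steps from compound 3 and from compound 2 cannot be read. The compounds shown leave open whether hydroxymethyl in place of cyano changes the result in this assay at all.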